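This account rests on a few compounds, and the source may have more. Where it says the series, first, only, none or still open, it means among the compounds named here.

Compounds measured in a functional assay on MCF7 cells (Homo sapiens), tested at 2.5 uM; on this read-out lower numbers stand for a stronger effect and higher numbers for a weaker effect at the one concentration tested:
- compound 1 `Cc1c(C)c2c(c(C)c1OC(=O)CCC(=O)O)CCC(C)(COc1ccc(/C=C3\SC(=O)NC3=O)cc1)O2`, 115%
- compound 2 `CC(C)=CCOc1c(C)c(C)c2c(c1C)CCC(C)(COc1ccc(/C=C3\SC(=O)NC3=O)cc1F)O2`, 95%
- compound 3 `COc1cc(/C=C2\SC(=O)NC2=O)ccc1OCC1(C)CCc2c(C)c(OCC=C(C)C)c(C)c(C)c2O1`, 95%

Compound 1 stands highest of the three, with compound 2 and compound 3 both lower by a margin beyond the scatter. The next compound, compound 4 `C=CCOc1c(C)c(C)c2c(c1C)CCC(C)(COc1ccc(/C=C3\SC(=O)NC3=O)cc1)O2`, differs from compound 1 in one place: allyl in place of (2-carboxyethyl)carbonyl on an oxygen on an aromatic ring. Within the data shown here, the only measured step, no change at the digits printed from compound 2 to compound 3 (within the scatter), concerns a different position and so says nothing about the change at the oxygen on the aromatic ring. Compound 2 and compound 3 both carry an alkenyl chain on that oxygen rather than a carboxylic acid, and both sit lower than compound 1, which points toward a drop for compound 4. The expected step of a number 20 percentage points lower from compound 1 to compound 4 (beyond the scatter) is therefore downward, beyond the scatter. Compound 4 is estimated at 95%, between 78% and 112%.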

Compound 4, a percentage reported as activity, at one concentration (the size of the read-out at that concentration, not a potency): 45%
Compound 4: the middle estimate sits 50 percentage points above what was measured; the measured number lies below the stated range.
By their numbers in this assay, from the lowest: compound 4; then compounds 2 and 3 (each within the scatter of the next); then compound 1.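

In this assay, the group on an oxygen on an aromatic ring proves decisive: allyl in place of (2-carboxyethyl)carbonyl brings a number 70 percentage points lower from compound 1 to compound 4 (beyond the scatter). Among these compounds, the only earlier step concerned a different position, so this is the first sign that the read-out responds to a change at this oxygen. Nothing available explains why the step is so large.

The compounds shown leave open whether the step belongs to allyl itself or to the loss of the carboxylic acid. A propyl chain, an acetyl group or a free hydroxyl on that oxygen would separate the two.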